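The compounds below may be only part of what the source reports. "The series", "measured", "known", "first", "only" and "open" are said of these compounds alone.

Compound 1, `CCN(CC)CC(=O)Nc1ccc(-c2nc3cc(C(F)(F)F)ccc3n2C)cc1`: 57000 nM
Compound 2, `O=C(CN1CCCC1)Nc1ccc(-c2nc3cc(C(F)(F)F)ccc3[nH]2)cc1`: 15000 nM
Compound 3, `O=C(CN1CCCC1)Nc1ccc(-c2nc3ccccc3[nH]2)cc1`: 70000 nM

In an ADME assay on MDBK cells (Bos taurus) for cytotoxicity, read by MTT assay, with a stated time of 96 h (a lower number here means that less compound is tolerated, a higher number that more compound is tolerated), compound 2 gives the lowest of these three numbers; compound 1 and compound 3 both sit higher, and the move from compound 2 to compound 3, hydrogen in place of trifluoromethyl on an aromatic carbon, is a 4.7-fold higher number from compound 2 to compound 3 (0.67 log units; beyond the scatter). Compound 4 `COc1ccc(-c2nc3cc(C(F)(F)F)ccc3[nH]2)cc1` differs from compound 2 in another way: methoxy in place of (((pyrrolidin-1-yl)methyl)carbonyl)amino on an aromatic carbon. Going by the values given here, none of the measured steps touches this position, so the measured data give no guide to its size or direction. The expectation is therefore a number near that of compound 2, with the step of a 1.3-fold higher number from compound 2 to compound 4 (0.12 log units; within the scatter) expected to stay within the scatter. Compound 4 is estimated at 20000 nM, ranging from 7000 nM to 60000 nM.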

Compound 4, half-maximal cytotoxic concentration: > 100000 nM
Compound 4 was reported as a limit; the forecaster's own chance of this, stated with the estimate: 15%; middle value at least 5.0-fold (0.69 log units) from the limit.
By their numbers in this assay, from the lowest: compound 2; then compounds 1 and 3 (each within the scatter of the next). At a limit, above all of these: compound 4.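

In this assay compound 4 gives > 100000 nM, which is a limit of the assay. Going by these compounds alone, putting methoxy in place of (((pyrrolidin-1-yl)methyl)carbonyl)amino on this aromatic carbon gives an at least 6.6-fold higher number from compound 2 to compound 4 (0.82 log units; beyond the scatter), so this position, which no earlier step touched, clearly moves the number and does so upward. The full size of the step cannot be read: the limit of > 100000 nM in this assay, at which 1 of the 4 values shown sits.

The compounds shown do not separate the contribution of the pyrrolidine ring from that of the amide link. They also leave open how a free amine, a hydroxyl or a simple hydrogen on this carbon would read.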